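A swapped group on a weak compound

A few compounds are considered here, and "the series" means these few. Any claim that something is new, unique, unknown or untested is made for them only; others in the source may bear on it.

In a functional assay on HL-60 cells (Homo sapiens) for inhibition, read by CCK-8 assay, with a stated time of 48 h (a lower number here means a stronger inhibitor, a higher number a weaker inhibitor), compound 1 (`COc1ccc(NC(=O)NCCNS(=O)(=O)c2ccc(-c3ccccc3OCc3ccccc3)s2)cc1`) gives > 50000 nM as its reading, which is a limit of the assay and not a number. Compound 2 (`O=C(NCCNS(=O)(=O)c1ccc(-c2ccccc2OCc2cccc(O)c2)s1)Nc1cc(Cl)cc(Cl)c1`) gives 2800 nM as a true number, so a compound of this set can register a measurable inhibition in this test.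

Compound 3 (`O=[N+]([O-])c1ccc(NC(=S)NCCNS(=O)(=O)c2ccc(-c3ccccc3OCc3ccccc3)s2)cc1`) keeps the core of compound 1 and differs from it in one place. On an amine nitrogen, the (4-methoxyphenyl)carbamoyl leaves and a group with no common name enters (a group of 12 heavy atoms (7 carbon, 2 nitrogen, 2 oxygen, 1 sulfur; one six-membered aromatic ring of carbon only) in place of a group of 11 heavy atoms (8 carbon, 1 nitrogen, 2 oxygen; one six-membered aromatic ring of carbon only), on an amine nitrogen). Going by the values given here, no measured pair shows what this kind of swap does, so any forecast here is loose.

Among the compounds with values here, with compound 2 at 2800 nM as the only true number to lean on, a move toward stronger inhibition is expected, though not a large one. The estimated change is an at least 3.3-fold lower number from compound 1 to compound 3 (0.52 log units; beyond the scatter) as a rough guide, and a reading that stays at the limit remains quite possible. In this assay the estimate for compound 3 is 15000 nM as the expected value, with 4000 nM as the low end and 50000 nM as the high end of the expected range.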

Compound 3, half-maximal inhibitory concentration: > 50000 nM
Compound 3 was reported as a limit; the forecaster's own chance of this, stated with the estimate: 35%; middle value at least 3.3-fold (0.52 log units) from the limit.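

In this assay compound 3 gives > 50000 nM, which is a limit and not a number. Compound 1 also sits at a limit, so no step from one to the other can be read: the limit of > 50000 nM in this assay, at which 2 of the 3 values shown sit.

The compounds shown leave open whether replacing the (4-methoxyphenyl)carbamoyl on the amine nitrogen changes inhibition at all.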